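Tertiary Amine Homologue of Compound 1 in Sigma Binding

This account rests on a few compounds, and the source may have more. Where it says the series, first, only, none or still open, it means among the compounds named here.

Going by the values given here, compound 1 `NCC[C@@H]1CCO[C@H](c2ccccc2)O1` gives 165 nM in an assay for displacement of a labelled ligand from Sigma non-opioid intracellular receptor 1 (Cavia porcellus), read by scintillation counting (a lower number here means a stronger inhibitor, a higher number a weaker inhibitor), and holds the only full number among the two values shown. Compound 2 `NCC[C@@H]1CCOC(c2ccccc2)(c2ccccc2)O1` returns in this assay only a limit, > 10000 nM, as noted in the limit of > 10000 nM in this assay, at which 1 of the 2 values shown sits. Compound 3 `CN(C)CCC[C@@H]1CCO[C@H](c2ccccc2)O1` differs from compound 1 by (dimethylamino)methyl in place of amino on a saturated chain carbon, two bonds along the chain from a saturated ring carbon. Among the compounds with values here, no measured step covers such a change, so the expectation rests on compound 1 alone. The expected step is a 5.5-fold lower number from compound 1 to compound 3 (0.74 log units; beyond the scatter), toward stronger binding and beyond the usual scatter. Compound 3 is accordingly estimated at 30 nM, within a range from 8 nM to 150 nM.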

Compound 3, inhibition constant: 1220 nM
Estimate against measurement, compound 3: 41-fold (1.61 log units) below, and the stated range ends below it.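

In this assay, the amino end of the chain now has a measured step: (dimethylamino)methyl in place of amino gives a 7.4-fold higher number from compound 1 to compound 3 (0.87 log units; beyond the scatter), toward weaker binding. Compound 3 still gives a full number, 1220 nM. Nothing shown accounts for this step. The change adds both chain length and methyl groups, and the compounds shown leave open which of these matters. A 3-aminopropyl chain or a 2-(dimethylamino)ethyl chain on the core of compound 1 would separate the two.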